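A few compounds are considered here, and "the series" means these few. Any claim that something is new, unique, unknown or untested is made for them only; others in the source may bear on it.

Compound 3 `CCN(Cc1ccccc1)C(=O)c1nn(-c2ccc(F)cc2)c(OC[C@@H](O)C[C@@H](O)CC(=O)O)c1C(C)C` gives the highest of the three numbers in an assay on microsomes from liver for inhibition of 3-hydroxy-3-methylglutaryl-coenzyme A reductase (Rattus norvegicus) (a higher number here means a weaker inhibitor, a lower number a stronger inhibitor), reading 14 nM. Its closest neighbour is compound 1 `CC(C)c1c(C(=O)N(C)Cc2ccccc2)nn(-c2ccc(F)cc2)c1CC[C@@H](O)C[C@@H](O)CC(=O)O`, which in this assay gives 6.2 nM, while compound 2 `Cc1ccc(CNC(=O)c2nn(-c3ccc(F)cc3)c(CC[C@@H](O)C[C@@H](O)CC(=O)O)c2C(C)C)cc1` lies furthest away and in this assay gives 2.5 nM. Compound 4 `CC(C)c1c(C(=O)NCC2CCCCC2)nn(-c2ccc(F)cc2)c1OC[C@@H](O)C[C@@H](O)CC(=O)O` has not yet been measured; it differs from compound 3 by (cyclohexylmethyl)amino in place of benzyl(ethyl)amino on a carbonyl carbon. Among the compounds with values here, the only measured step that touches this kind of change is a 2.5-fold lower number from compound 1 to compound 2 (0.39 log units; beyond the scatter), where a tertiary benzyl amide became a secondary amide bearing a methyl-substituted benzyl group and the number fell by a modest amount. Within the data shown here, compound 4 likewise trades a tertiary amide for a secondary one, though its ring is saturated rather than aromatic, and no measured pair speaks to that part of the change. A step of similar size and direction is therefore expected, a 2.0-fold lower number from compound 3 to compound 4 (0.30 log units; within the scatter), with some spread allowed for the untested ring change. Compound 4 is estimated to give 7 nM in this assay, within a range from 3 nM to 20 nM.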

Compound 4, half-maximal inhibitory concentration: 17 nM
The estimate for compound 4 lay 2.4-fold (0.39 log units) below the measured number; measured number inside the range.
By their numbers in this assay, from the lowest: compound 2; then compound 1; then compounds 3 and 4 (each within the scatter of the next).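

In this assay the change reads as a 1.2-fold higher number from compound 3 to compound 4 (0.08 log units; within the scatter) and so, on this carbonyl carbon, (cyclohexylmethyl)amino stands in for benzyl(ethyl)amino without a readable change, even though it brings the amide hydrogen and a non-aromatic ring in place of the aromatic one. Going to a secondary amide at this position therefore does not by itself repeat a 2.5-fold lower number from compound 1 to compound 2 (0.39 log units; beyond the scatter) in every pair shown. Nothing given here accounts for the difference between these two steps.

The compounds shown leave open whether (4-methylbenzyl)amino would lower the number when it replaces benzyl(ethyl)amino in compound 3, and so whether the earlier step depends on the rest of the molecule. They also leave open how a morpholine amide or a hydroxyl group on the cyclohexyl ring would read at this position.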